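This account rests on a few compounds, and the source may have more. Where it says the series, first, only, none or still open, it means among the compounds named here.

Measured so far:
Compound 1, `CCCCCCc1nc(-c2ccc(CNC(=O)[C@H]3NCC[C@@H]3O)cc2)no1`, which in an assay on isolated protein for inhibition of sphingosine kinase 1 (Homo sapiens) (a higher number here means a weaker inhibitor, a lower number a stronger inhibitor), gives 49 nM.
Compound 2, `CCCCCCCc1nc(-c2ccc(CNC(=O)[C@H]3NCC[C@@H]3O)cc2)nn1C`, which in this assay gives 610 nM.

Compound 1 holds the lower of the two numbers, and the gap separating compound 1 from compound 2 lies beyond the usual scatter of repeated measurements. For the measured compounds named here, compound 2 differs from compound 1 in more than one part of the structure, so the two values show only that compound 1 is the stronger inhibitor of the pair; no single change can be credited.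

Compound 3, `CCCCCc1nc(-c2ccc(CNC(=O)[C@H]3NCC[C@@H]3O)cc2)no1`, is still to be measured. Going by the values given here, its only change from compound 1 is hydrogen in place of methyl on a saturated chain carbon, five bonds along the chain from an aromatic carbon. Among the compounds with values here, with no measured step of this kind to lean on, the expectation is a modest move towards a higher number, described by a 1.8-fold higher number from compound 1 to compound 3 (0.26 log units; within the scatter), not far beyond the scatter. Compound 3 is therefore expected to give about 90 nM in this assay, within a range from 35 nM to 250 nM.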

Compound 3, half-maximal inhibitory concentration: 430 nM
Estimate against measurement, compound 3: 4.8-fold (0.68 log units) below, outside the stated range (above it).
By their numbers in this assay, from the lowest: compound 1; then compounds 3 and 2 (each within the scatter of the next).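

Losing one carbon from the chain has a clear cost: in this assay, hydrogen in place of methyl on a saturated chain carbon, five bonds along the chain from an aromatic carbon, gives an 8.8-fold higher number from compound 1 to compound 3 (0.94 log units; beyond the scatter). For the compounds shown here, the pair of compound 1 and compound 2 differed in more than one place, so this is the first single change that can be credited with a loss of inhibition, and it shows that this position on the chain is sensitive even to a group as small as methyl. Nothing measured here explains why so small a change counts for so much.

Going by these compounds alone, with only this one step, it remains open whether a longer chain on the core of compound 1 would lower the number or raise it. Also open, going by these compounds, is how a chain carrying an amine or a carboxylic acid would compare.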